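The source may report more compounds than this note shows. Statements on the series, on what has been measured and on what is new or still open speak of the compounds shown alone.

Compound 1 `COc1ccc(/C=C2\CN(C(=S)SCc3cn(Cc4ccc(F)cc4)nn3)C/C(=C\c3ccc(OC)cc3)C2=O)cc1` carries a 4-fluorobenzyl group on the shared core. In a functional assay on MCF7 cells (Homo sapiens) for cytotoxicity, read by MTT assay, with a stated time of 24 h (on this read-out lower numbers stand for stronger inhibition and higher numbers for weaker inhibition), compound 1 gives only a limit, > 100000 nM. Compound 2 `Cc1ccc(/C=C2\CN(C(=S)SCc3cn(Cc4ccc(F)cc4)nn3)C/C(=C\c3ccc(C)cc3)C2=O)cc1` has a different core; the difference between the two cores is not broken down here. In this assay compound 2 gives 81600 nM. Compound 3 `Cc1ccc(/C=C2\CN(C(=S)SCc3cn(Cc4cccc(Cl)c4)nn3)C/C(=C\c3ccc(C)cc3)C2=O)cc1` differs from compound 2 by 3-chlorophenyl in place of 4-fluorophenyl on a saturated chain carbon bound to an aromatic nitrogen. In this assay compound 3 gives only a limit, > 100000 nM. The measured step of an at least 1.2-fold higher number from compound 2 to compound 3 (0.08 log units; that floor lies within the scatter) therefore ends at a limit, in keeping with the limit of > 100000 nM in this assay, at which 2 of the 3 values shown sit.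

Compound 4 `COc1ccc(/C=C2\CN(C(=S)SCc3cn(Cc4cccc(Cl)c4)nn3)C/C(=C\c3ccc(OC)cc3)C2=O)cc1` is not yet measured. It differs from compound 1 by 3-chlorophenyl in place of 4-fluorophenyl on a saturated chain carbon bound to an aromatic nitrogen, the same change at the same place as from compound 2 to compound 3. Among the measured compounds shown here, compound 1 already stands at a limit, and the one measured instance of this change left potency essentially unchanged. For compound 4 the expected step is a step that the limit leaves unreadable from compound 1 to compound 4, resting on the measured step of an at least 1.2-fold higher number from compound 2 to compound 3 (0.08 log units; that floor lies within the scatter) and on compound 1 standing at a limit. Compound 4 is therefore estimated at 150000 nM in this assay, between 60000 nM and 400000 nM, most likely reported only as a limit.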

Compound 4, half-maximal inhibitory concentration: 32000 nM
Compound 4: the middle estimate sits 4.7-fold (0.67 log units) above what was measured, and the stated range ends above it.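

In this assay, the change from 4-fluorobenzyl to 3-chlorobenzyl on the core of compound 1 gives an at least 3.1-fold lower number from compound 1 to compound 4 (0.49 log units; beyond the scatter), so the change can lower the number on this core. It does not carry over with the same size between the two cores: the same change on two cores in this assay, an at least 1.2-fold higher number (0.08 log units; that floor lies within the scatter) from compound 2 to compound 3 and an at least 3.1-fold lower number (0.49 log units; beyond the scatter) from compound 1 to compound 4, at least 3.8-fold (0.58 log units) apart, beyond the scatter of two such steps Each step has a limit at one end, so both are bounds and not exact sizes, the pair shows no cause for the gap between the cores, and two cores are too few for a rule across the series: the limit of > 100000 nM in this assay, at which 2 of the 4 values shown sit.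

Still open, as far as these compounds go, is whether the step on the core of compound 1 comes from the chlorine or from its placement, as the two compounds differ in both at once. Also open, from the compounds shown here alone, is how a plain benzyl group, or a benzyl carrying an amine or a carboxylic acid, would read on either core, and whether any such group would bring compound 2 and compound 3 clear of the limit region.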